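This account rests on a few compounds, and the source may have more. Where it says the series, first, only, none or still open, it means among the compounds named here.

The measured compounds in a functional assay on HeLa cells (Homo sapiens) for cytotoxicity, read by MTT assay, with a stated time of 48 h; a lower number here means a stronger inhibitor, a higher number a weaker inhibitor:
Compound 1 `Cc1n[nH]c2c1C(c1ccc(N(C)C)cc1)C(C(=O)NNC(N)=S)=C(N)N2`, 6260 nM.
Compound 2 `Cc1n[nH]c2c1C(c1ccc(N(C)C)cc1)C(C(=O)O)=C(N)N2`, 33600 nM.
Compound 3 `Cc1n[nH]c2c1C(c1ccc(N(C)C)cc1)C(C(=O)N/N=C1/C(=O)Nc3ccccc31)=C(N)N2`, 52900 nM.

Compound 3 has the highest number of the three. Its number and that of compound 2 lie within the scatter of each other, so nothing can be said about their order. Against compound 1 the gap is wider: an 8.5-fold higher number from compound 1 to compound 3 (0.93 log units; beyond the scatter). The other measured step, a 5.4-fold higher number from compound 1 to compound 2 (0.73 log units; beyond the scatter), also moves away from compound 1, in the same direction.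

Compound 4 `Cc1n[nH]c2c1C(c1ccc(N(C)C)cc1)C(C(=O)N/N=C/c1ccc(Cl)cc1)=C(N)N2` differs from compound 3 on the amide-type nitrogen that also separates compound 3 from compound 1: a group of 9 heavy atoms (7 carbon, 1 nitrogen, 1 chlorine; one six-membered aromatic ring of carbon only) in place of a group of 11 heavy atoms (8 carbon, 2 nitrogen, 1 oxygen; one five-membered non-aromatic ring with 1 hetero atom, one six-membered aromatic ring of carbon only), on an amide-type nitrogen. Within the data shown here, only one measured step touches this nitrogen, the one from compound 1 to compound 3, and there the group of 11 heavy atoms gave a higher number than the group of 4 heavy atoms of compound 1. Compound 4 keeps a group of 9 heavy atoms in the same place, so no return to the level of compound 1 is expected. The step is expected to be small, a 2.1-fold lower number from compound 3 to compound 4 (0.33 log units; beyond the scatter), within or close to the scatter. Compound 4 is therefore estimated at 25000 nM, with a range from 7000 nM to 70000 nM.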

Compound 4, half-maximal inhibitory concentration: 31700 nM
The estimate for compound 4 lay 1.3-fold (0.10 log units) below the measured number; low and high end bracket the measured number.
By their numbers in this assay, from the lowest: compound 1; then compounds 4, 2 and 3 (each within the scatter of the next).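

In this assay, putting the group of 9 heavy atoms with its chlorine in place of the group of 11 heavy atoms on the amide-type nitrogen left the number within the scatter (a 1.7-fold lower number from compound 3 to compound 4 (0.22 log units; within the scatter)), so this position does not tell these two large groups apart, although they differ in ring count and in hydrogen-bond donors. Compound 4 also cannot be told apart from the carboxylic acid (a 1.1-fold lower number from compound 2 to compound 4 (0.03 log units; within the scatter)), yet it remains beyond the scatter from the compound carrying the group of 4 heavy atoms (a 5.1-fold higher number from compound 1 to compound 4 (0.70 log units; beyond the scatter)), so among these four compounds, compound 1 alone stands apart, while compounds 2, 3 and 4 form one level. Nothing available here gives a reason for this grouping.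

The compounds shown leave open whether the lower number of compound 1 depends on its sulfur, as a urea carbonyl with oxygen in that place could show, or on the whole chain, as a plain hydrazide with a free amine could show. They also leave open whether the chlorine in compound 4 matters, since a methoxy group or a hydrogen in its place is not among them.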